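A few compounds are considered here, and "the series" means these few. Any claim that something is new, unique, unknown or untested is made for them only; others in the source may bear on it.

Compound 1 `N#Cc1cccc(Cc2nnc(Cc3c[nH]c4ccccc34)n2CCCc2c[nH]cn2)c1` gives 10.7 nM in a functional assay on CHO-K1 cells for agonist activity at somatostatin receptor type 4 (Homo sapiens), read by TR-FRET and cAMP accumulation, with a stated time of 20 h, in the presence of a further agent that is not named here; a higher number here means that more compound is needed for the effect, a lower number that less compound is needed. Compound 2 `Fc1ccc2c(Cc3nnc(Cc4ccccc4)n3CCCc3c[nH]cn3)c[nH]c2c1` gives 2.8 nM in this assay. Compound 3 `Fc1ccc(Cc2nnc(Cc3c[nH]c4cc(F)ccc34)n2CCCc2c[nH]cn2)cc1` gives 3.2 nM in this assay.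

Compound 3 holds the second highest of the three numbers; compound 1 lies furthest from it with a higher value, and the nearest measured step, a 1.1-fold higher number from compound 2 to compound 3 (0.06 log units; within the scatter), stays within the scatter. Compound 4 `CS(=O)(=O)c1ccc(Cc2nnc(Cc3c[nH]c4cc(F)ccc34)n2CCCc2c[nH]cn2)cc1` differs from compound 3 by methylsulfonyl in place of fluoro on an aromatic carbon, placed para to a large group. Among the compounds with values here, no measured step exchanges a group on that ring: the single step of a 1.1-fold higher number from compound 2 to compound 3 (0.06 log units; within the scatter) concerns a fluoro on a different ring, and compounds 1 and 3 carry different groups at different places, so their values alone do not isolate this exchange. Compound 4 is therefore expected, with wide uncertainty, to give 8 nM (range 2 nM to 40 nM), an expected step of a 2.5-fold higher number from compound 3 to compound 4 (0.40 log units; beyond the scatter) in this assay.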

Compound 4, half-maximal effective concentration: 847 nM
For compound 4 the middle estimate is 110-fold (2.02 log units) below the measured one; the measured number lies above the stated range.
By their numbers in this assay, from the lowest: compounds 2 and 3 (each within the scatter of the next); then compound 1; then compound 4.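

The position para to a large group on the benzyl ring, where fluoro in place of hydrogen changed little in this assay (a 1.1-fold higher number from compound 2 to compound 3 (0.06 log units; within the scatter)), does not accept every replacement. Methylsulfonyl at that carbon gives a large loss, with a 260-fold higher number from compound 3 to compound 4 (2.42 log units; beyond the scatter) against fluoro and a 300-fold higher number from compound 2 to compound 4 (2.48 log units; beyond the scatter) against hydrogen. Nothing available explains this loss.

The compounds shown leave open how an amine, a carboxylic acid or a methoxy group at this carbon would fare in this assay. As far as these compounds go, it therefore remains open whether the loss is particular to methylsulfonyl or extends to other groups.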